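The compounds below may be only part of what the source reports. "The series", "measured", "known", "first", "only" and "open" are said of these compounds alone.

Measured in a functional assay on HeLa cells (Homo sapiens) for cytotoxicity, read by XTT assay, with a stated time of 72 h; a lower number here means a stronger inhibitor, a higher number a weaker inhibitor:
compound 1 `COc1ccc(C(O)c2ccc3c(ccn3C)c2)c(OC)c1OC`: 2400 nM
compound 2 `CCn1ccc2cc(C(O)c3ccc(OC)c(OC)c3OC)ccc21`: < 1000 nM, a limit of the assay, not a number
compound 3 `COc1ccc(/C(=N\O)c2ccc3c(ccn3C)c2)c(OC)c1OC`: 76 nM

Compound 3 gives the lowest of the two numbers, well clear of compound 1. How the core of compound 3 differs from the core of compound 1 is not broken down here. Between compound 1 and compound 2 the change is methyl in place of hydrogen on a saturated chain carbon bound to an aromatic nitrogen, and it gave an at least 2.4-fold lower number from compound 1 to compound 2 (0.38 log units; beyond the scatter); the size of that step rests on (the limit of < 1000 nM in this assay, at which 1 of the 3 values shown sits).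

Compound 4 `CCn1ccc2cc(/C(=N/O)c3ccc(OC)c(OC)c3OC)ccc21` carries the same change against compound 3: methyl in place of hydrogen on a saturated chain carbon bound to an aromatic nitrogen, at a place described in the same words. In this assay the expected step is a 2.2-fold lower number from compound 3 to compound 4 (0.34 log units; beyond the scatter), resting on the measured at least 2.4-fold lower number from compound 1 to compound 2 (0.38 log units; beyond the scatter). For compound 4 the estimate is 35 nM, between 10 nM and 120 nM.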

Compound 4, half-maximal inhibitory concentration: 2000 nM
Beside the measured number, compound 4's estimate is 57-fold (1.76 log units) below it; the measured number lies above the stated range.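

In this assay, methyl in place of hydrogen on a saturated chain carbon bound to an aromatic nitrogen gives a 26-fold higher number from compound 3 to compound 4 (1.42 log units; beyond the scatter), so the change does not carry over from one core to the other in this series: the same change on two cores in this assay, an at least 2.4-fold lower number (0.38 log units; beyond the scatter) from compound 1 to compound 2 and a 26-fold higher number (1.42 log units; beyond the scatter) from compound 3 to compound 4, at least 63-fold (1.80 log units) apart, beyond the scatter of two such steps. Compound 2 gives < 1000 nM, a limit of the assay and not a number, so the earlier step has no exact size. The two pairs show that the outcome of this change differs with the core, but not what in the cores sets that difference, nor how the change would read on a further core.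

Open, going by these compounds, is how a longer chain, such as propyl, or a chain ending in an amine, would read in the same place on each core.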